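Amide-to-sulfonyl swap on the shared core

This account rests on a few compounds, and the source may have more. Where it says the series, first, only, none or still open, it means among the compounds named here.

Compound 1 `O=C(Nc1cccc(/C=C/C(=O)c2nc3ccccc3[nH]2)c1)c1cccc(Br)c1` is the reference for this set. In a functional assay on MCF7 cells (Homo sapiens) for antiproliferative activity, read by MTT assay, with a stated time of 48 h (a higher number here means a weaker inhibitor, a lower number a stronger inhibitor), compound 1 gives 5210 nM, the lowest of the three numbers measured. Compound 2 `O=C(Nc1cccc(/C=C/C(=O)c2nc3ccccc3[nH]2)c1)c1cccc(C(F)(F)F)c1` gives 21500 nM and compound 3 `COc1cccc(C(=O)Nc2cccc(/C=C/C(=O)c3nc4ccccc4[nH]3)c2)c1` gives 17800 nM. Both changes on the aryl ring raise the number: a 4.1-fold higher number from compound 1 to compound 2 (0.62 log units; beyond the scatter) and a 3.4-fold higher number from compound 1 to compound 3 (0.53 log units; beyond the scatter), while a 1.2-fold lower number from compound 2 to compound 3 (0.08 log units; within the scatter).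

Compound 4 `O=C(/C=C/c1cccc(NS(=O)(=O)c2ccccc2Cl)c1)c1nc2ccccc2[nH]1` differs from compound 1 in a different way: (2-chlorophenyl)sulfonyl in place of (3-bromophenyl)carbonyl on a nitrogen on an aromatic ring. Within the data shown here, no measured step touches the linker itself; the two steps that exist only vary the substituent on the same aromatic ring, and each of them moves the number up by a modest amount. The change in compound 4 is larger than either, replacing both the substituent and its position and the connecting group. The expectation for compound 4 is therefore a higher number than compound 1, with a step roughly like a 2.3-fold higher number from compound 1 to compound 4 (0.36 log units; beyond the scatter), but the range is wide. Compound 4 is estimated at 12000 nM, between 4000 nM and 40000 nM.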

Compound 4, half-maximal inhibitory concentration: 4280 nM
Compound 4: middle estimate off by 2.8-fold (0.45 log units), on the high side, within the range that was stated.
By their numbers in this assay, from the lowest: compounds 4 and 1 (each within the scatter of the next); then compounds 3 and 2 (each within the scatter of the next).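

In this assay, (2-chlorophenyl)sulfonyl in place of (3-bromophenyl)carbonyl on this nitrogen leaves the number within the scatter, with a 1.2-fold lower number from compound 1 to compound 4 (0.09 log units; within the scatter). Against the methoxy amide the same kind of swap gives a 4.2-fold lower number from compound 3 to compound 4 (0.62 log units; beyond the scatter), so at this nitrogen the carbonyl link is not required for a number in the range of compound 1, even with the connecting group and the aryl substituent changed together. Nothing available accounts for this result.

From the compounds shown here alone, compound 4 changes the connecting group and the aryl substituent in one step, so the share of each in these steps remains open. Also open, going by these compounds, is how the number in this assay would respond to an amine or a carboxylic acid on the aryl ring of the sulfonyl compound.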